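This account rests on a few compounds, and the source may have more. Where it says the series, first, only, none or still open, it means among the compounds named here.

Measured in a functional assay on HT-29 cells (Homo sapiens) for inhibition, read by sulforhodamine B assay, with a stated time of 72 h; on this read-out higher numbers stand for weaker inhibition and lower numbers for stronger inhibition:
- compound 1 `COc1cc(N2C(=O)CC2c2ccc(SC)cc2)cc(OC)c1OC`: 108 nM
- compound 2 `CCSc1ccc(C2C(O)C(=O)N2c2cc(OC)c(OC)c(OC)c2)cc1`: 12 nM
- compound 3 `COc1ccc(C2C(Oc3ccccc3)C(=O)N2c2cc(OC)c(OC)c(OC)c2)cc1`: 52 nM

Compound 1, at 108 nM, has the highest number of the three, so it is the weakest inhibitor here. Compound 3 comes nearest to it and compound 2 lies furthest away, and both gaps are beyond the scatter.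

Compound 4 `COc1cc(N2C(=O)C(C3CC3)C2c2ccc(SC)cc2)cc(OC)c1OC` keeps the core of compound 1 but has cyclopropyl in place of hydrogen on a saturated ring carbon. Its value is not yet known.

Among the compounds with values here, no pair of measured compounds differs by this change alone, so any forecast rests on loose evidence. Compound 2 at 12 nM and compound 3 at 52 nM also carry a group other than hydrogen on that ring carbon, and both have lower numbers than compound 1. They differ from compound 1 elsewhere as well, so they serve only as a rough guide.

A moderate fall in the number is therefore expected in this assay, although a change within the scatter remains possible. The estimated step is a 2.7-fold lower number from compound 1 to compound 4 (0.43 log units; beyond the scatter). In this assay the estimated value for compound 4 is 40 nM, with an expected range from 10 nM to 160 nM.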

Compound 4, half-maximal inhibitory concentration: 204 nM
For compound 4 the middle estimate is 5.1-fold (0.71 log units) below the measured one; measured number outside the range, above it.
By their numbers in this assay, from the lowest: compound 2; then compound 3; then compounds 1 and 4 (each within the scatter of the next).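

In this assay, cyclopropyl in place of hydrogen on a saturated ring carbon gives a 1.9-fold higher number from compound 1 to compound 4 (0.28 log units; within the scatter), and this pair is the only direct reading of a change at this carbon among the compounds shown. The step therefore gives no ground to claim a real difference between the two compounds: the shared core accepts this three-membered ring of carbon here without a shift that repeated measurements could distinguish from noise. It also shows that a group other than hydrogen on this ring carbon does not by itself bring a lower number, and nothing in the data accounts for this result.

Going by these compounds, compounds 2 and 3 differ from compound 1 in more than one place, so what a hydroxyl or phenoxy group would do on the core of compound 1, with nothing else altered, stays open. So does the effect on that same core of an amine, a carboxylic acid or a longer chain such as n-butyl at this ring carbon.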